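From phenyl to 4-methoxyphenyl: an expected small step

The compounds below may be only part of what the source reports. "The series", "measured", "known", "first", "only" and "open" are said of these compounds alone.

Measured in a functional assay on HeLa cells (Homo sapiens) for antiproliferative activity, read by MTT assay, with a stated time of 48 h; a lower number here means a stronger inhibitor, a higher number a weaker inhibitor:
- Compound 1 `Fc1ccc2[nH]c(-c3cn(-c4ccccc4)nc3-c3ccccc3)nc2c1` gives 3610 nM
- Compound 2 `COc1ccc2[nH]c(-c3cn(-c4ccccc4)nc3-c3ccccc3)nc2c1` gives 2870 nM

Only these two compounds have been measured, and their values lie within the scatter of each other, so compound 1 cannot be ranked against compound 2. The next compound, compound 3 `COc1ccc(-c2nn(-c3ccccc3)cc2-c2nc3cc(F)ccc3[nH]2)cc1`, has not yet been measured. It differs from compound 1 by one change, (methoxy in place of hydrogen on an aromatic carbon), which reads as phenyl to 4-methoxyphenyl when cut one bond further out.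

Among the compounds with values here, the only measured step, a 1.3-fold lower number from compound 1 to compound 2 (0.10 log units; within the scatter), also brings in a methoxy, but in place of fluoro rather than hydrogen. It therefore bears on the new change only indirectly. Within the data shown here, no measured compound shows the phenyl to 4-methoxyphenyl change itself, so the direction remains open, and no step beyond the scatter is expected in this assay. The estimate amounts to an expected 1.2-fold lower number from compound 1 to compound 3 (0.08 log units; within the scatter). For compound 3 the estimated value is 3000 nM, with an expected range from 1000 nM to 8000 nM.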

Compound 3, half-maximal inhibitory concentration: 1740 nM
Beside the measured number, compound 3's estimate is 1.7-fold (0.24 log units) above it; low and high end bracket the measured number.
By their numbers in this assay, from the lowest: compounds 3, 2 and 1 (each within the scatter of the next, the first and the last beyond it).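

In this assay, within the data shown here, the phenyl to 4-methoxyphenyl change gives a 2.1-fold lower number from compound 1 to compound 3 (0.32 log units; beyond the scatter) and so provides the first step in this small set that lies beyond the scatter, though only modestly. It shows that methoxy in place of hydrogen on this six-membered aromatic ring of carbon only, para to a large group, lowers the number in this one pair, whereas the earlier exchange of fluoro for methoxy at a different place gave a 1.3-fold lower number from compound 1 to compound 2 (0.10 log units; within the scatter) and stayed within the scatter. Nothing measured alongside these values accounts for the step.

Going by these compounds, with one pair at this position, it remains open whether the step belongs to methoxy in particular or would also appear with a hydroxyl group, a chlorine atom or a dimethylamino group, and whether a longer chain such as ethoxy would lower the number further or raise it. On these data alone, it is equally open whether the same change would give a step of like size and direction on the core of compound 2, which carries methoxy rather than fluoro.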